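This account rests on a few compounds, and the source may have more. Where it says the series, first, only, none or still open, it means among the compounds named here.

Notes on the series built around the core of compound 1 `Cc1ccc(CS/C(=C/c2ccc(F)c(C)c2)C(=O)c2ccc(Cl)cc2)cc1`. In a functional assay on DU-145 cells (Homo sapiens) for inhibition, read by trypan blue exclusion, with a stated time of 96 h (on this read-out higher numbers stand for weaker inhibition of growth and lower numbers for stronger inhibition of growth), compound 1 gives 25000 nM. Compound 2 `COc1ccccc1/C=C(/SCc1ccc(Cl)cc1)C(=O)c1ccc([N+](=O)[O-])cc1` in this assay gives 10000 nM. Compound 3 `Cc1ccc(S/C(=C/c2ccc(C)s2)C(=O)c2ccc(Br)cc2)cc1` is reported in this assay only as a limit, > 100000 nM; this is the limit of > 100000 nM in this assay, at which 1 of the 3 values shown sits. Among the two plain numbers compound 1 stands highest, with compound 2 lying one step lower, a step beyond the usual scatter.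

Compound 4 `Cc1ccc(CS/C(=C/c2ccccc2Br)C(=O)c2ccc(Cl)cc2)cc1` has not yet been measured in this assay. It differs from compound 1 in a single place: 2-bromophenyl in place of 4-fluoro-3-methylphenyl on a double-bonded chain carbon bound to a double-bonded chain carbon. Within the data shown here, no measured pair in the set carries this exchange, so no step can be read off directly. The change keeps one six-membered aromatic ring of carbon only on the double-bonded chain carbon and alters only what sits on that ring, so the expected outcome is a step of no size beyond the scatter, with a wide range either way. The estimate means an expected step of no change at the digits printed from compound 1 to compound 4 (within the scatter). Compound 4 is accordingly estimated at 25000 nM, expected to fall between 8000 nM and 80000 nM.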

Compound 4, concentration for 50% growth inhibition: 10000 nM
Compound 4: the middle estimate sits 2.5-fold (0.40 log units) above what was measured; measured number inside the range.
By their numbers in this assay, from the lowest: compounds 2 and 4 (each within the scatter of the next); then compound 1. At a limit, above all of these: compound 3.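

In this assay, among these compounds, the exchange of 4-fluoro-3-methylphenyl for 2-bromophenyl on a double-bonded chain carbon bound to a double-bonded chain carbon gives a 2.5-fold lower number from compound 1 to compound 4 (0.40 log units; beyond the scatter) as the first step that can be read from a single change. The number at this position thus moves, modestly but beyond the scatter, even though one six-membered aromatic ring of carbon only stays in place and only what sits on that ring differs. No measurement shown bears on why the number moves in this direction.

On these data alone, whether the step belongs to the bromine, to the loss of the fluorine and the methyl, or to the two together stays open. Also open, as far as these compounds go, is how the same position would respond to a phenyl carrying an amine or a carboxylic acid in place of 2-bromophenyl.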